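A few compounds are considered here, and "the series" means these few. Any claim that something is new, unique, unknown or untested is made for them only; others in the source may bear on it.

Compound 2 `CC(C)c1n[nH]c2c(NCc3ccc(-c4ccccn4)cc3)nc(SCC(C)(C)N)nc12` holds the lowest of the two numbers in a functional assay on HT cells (Homo sapiens) for antiproliferative activity, read by fluorescence, with a stated time of 72 h; a higher number here means a weaker inhibitor of growth, a lower number a stronger inhibitor of growth: compound 2 gives 85 nM, while compound 1 `CC(C)c1n[nH]c2c(NCc3ccc(-c4ccccn4)cc3)nc(SCC(N)CN)nc12` gives 480 nM. Compound 3 `C=CCSc1nc(NCc2ccc(-c3ccccn3)cc2)c2[nH]nc(C(C)C)c2n1` differs from compound 2 in one place: vinyl in place of 1-amino-1-methylethyl on a saturated chain carbon bound to a sulfur. Among the compounds with values here, the only measured step at this position, a 5.6-fold lower number from compound 1 to compound 2 (0.75 log units; beyond the scatter), shows that altering the group on the saturated chain carbon bound to sulfur moves the number modestly, yet both measured compounds keep an amine there, so the data give no direct guide for losing it. A rise in this assay is expected, estimated as a 7.1-fold higher number from compound 2 to compound 3 (0.85 log units; beyond the scatter). Compound 3 is estimated at 600 nM, within 150 nM to 3000 nM.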

Compound 3, concentration for 50% growth inhibition: 1010 nM
Compound 3: middle estimate off by 1.7-fold (0.23 log units), on the low side; the measured number falls inside the stated range.
By their numbers in this assay, from the lowest: compound 2; then compound 1; then compound 3.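

With vinyl, the chain on sulfur carries no amine, and a 12-fold higher number from compound 2 to compound 3 (1.07 log units; beyond the scatter) in this assay is a large loss of growth inhibition. The same change gives a 2.1-fold higher number from compound 1 to compound 3 (0.32 log units; beyond the scatter), so both amine-bearing groups beat vinyl here, although the size of that loss depends on which amine group it replaces. No measurement shown explains these differences. This change removes the nitrogen and shortens the group together, so their contributions remain unseparated. A 2-hydroxy-2-methylpropyl group, with a hydroxyl in place of the amine, would leave open whether the nitrogen itself matters.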